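Carboxy in Place of Methoxy: Expectation for Compound 3

The source may report more compounds than this note shows. Statements on the series, on what has been measured and on what is new or still open speak of the compounds shown alone.

Compound 1 `COc1ccc(-c2cc(C(=O)c3ccccc3)c(N)s2)cc1` gives 31% in an assay on CHO cells for positive allosteric modulation of adenosine receptor A1 (Homo sapiens), read by ERK phosphorylation, tested at 3 uM (a lower number here means a stronger effect, a higher number a weaker effect of the compound at the concentration tested), the higher of the two numbers recorded, while compound 2 `Nc1sc(-c2cncnc2)cc1C(=O)c1ccccc1` gives 18% in this assay, a gap beyond the scatter. Compound 3 `Nc1sc(-c2ccc(C(=O)O)cc2)cc1C(=O)c1ccccc1` is still unmeasured; it differs from compound 1 by carboxy in place of methoxy on an aromatic carbon, on an aromatic carbon of a six-membered aromatic ring of carbon only. Within the data shown here, with no comparable step among the measured pair, only a small step is expected in this assay, likely within the scatter and, if anything, toward a weaker effect. Compound 3 is expected to give about 36%, within 15% to 60%, a step of a number 5 percentage points higher from compound 1 to compound 3 (within the scatter).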

Compound 3, a percentage reported as activity, at one concentration (the size of the read-out at that concentration, not a potency): 51%
For compound 3 the middle estimate is 15 percentage points below the measured one, within the range that was stated.
By their numbers in this assay, from the lowest: compound 2; then compound 1; then compound 3.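

In this assay, the position para to a large group on the six-membered aromatic ring of carbon only proves sensitive to this exchange: carboxy in place of methoxy gives a modest step toward a weaker effect, a number 20 percentage points higher from compound 1 to compound 3 (beyond the scatter). This is the only single-place change among the compounds shown, and it is one that moves the read-out beyond the scatter. Nothing available here bears on the reason for this step. Going by these compounds, it remains open whether an amine or a methyl ester at this position would stay closer to compound 1 or to compound 3.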